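Replacing the aryl group of the most potent compound

A few compounds are considered here, and "the series" means these few. Any claim that something is new, unique, unknown or untested is made for them only; others in the source may bear on it.

Compound 1 `NC1=NC2(CCSCC2)N(OCCCOc2ccc(Cl)c(Cl)c2)C(N)=N1`: 1 nM
Compound 2 `NC1=NC2(CCOCC2)N(OCCCOc2ccccc2Cl)C(N)=N1`: 2700 nM
Compound 3 `NC1=NC2(CCOCC2)N(OCCCOc2ccc(F)cc2)C(N)=N1`: 1060 nM

In a functional assay on A549 cells (Homo sapiens) for antiproliferative activity, read by MTT assay, with a stated time of 72 h (a lower number here means a stronger inhibitor, a higher number a weaker inhibitor), compound 1 gives 1 nM, the lowest of the three values and far beyond the scatter from the other two. Compound 3 follows at 1060 nM, and compound 2 gives 2700 nM.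

The next compound, compound 4 `NC1=NC2(CCSCC2)N(OCCCOc2cccc(Br)c2)C(N)=N1`, keeps the core of compound 1 and changes only the aryl group: 3-bromophenyl in place of 3,4-dichlorophenyl on an oxygen on a saturated carbon. In words, 3-bromophenyl stands in place of 3,4-dichlorophenyl on an oxygen on a saturated carbon.

Among the measured compounds shown here, only one measured step changes an aryl group alone, a 2.5-fold lower number from compound 2 to compound 3 (0.41 log units; beyond the scatter), and it is modest. However, it was measured on the core of compounds 2 and 3, not that of compound 1. For the measured compounds named here, it therefore offers only weak guidance, and no measured step shows this exact exchange.

With compound 1 at 1 nM, a moderate rise in this assay is expected, towards weaker inhibition. The expected change is a 30-fold higher number from compound 1 to compound 4 (1.48 log units; beyond the scatter). For compound 4 the estimated value is 30 nM. The expected range for compound 4 runs from 2 nM to 500 nM.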

Compound 4, half-maximal inhibitory concentration: 50 nM
Estimate against measurement, compound 4: 1.7-fold (0.22 log units) below; low and high end bracket the measured number.
By their numbers in this assay, from the lowest: compound 1; then compound 4; then compound 3; then compound 2.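

On the core of compound 1, the aryl group on an oxygen on a saturated carbon has a strong hold on the read-out: in this assay the exchange of 3,4-dichlorophenyl for 3-bromophenyl gives a 50-fold higher number from compound 1 to compound 4 (1.70 log units; beyond the scatter). Among the compounds shown here, the only earlier exchange of an aryl group alone, a 2.5-fold lower number from compound 2 to compound 3 (0.41 log units; beyond the scatter), was modest and stood on a different core, so this is the first sign of how much this position matters on the core of compound 1. Nothing at hand accounts for the size of the step.

The exchange replaces two chlorine atoms with one bromine atom, so the compounds shown cannot separate the effect of the kind of halogen from that of their number. On these data alone, how a phenyl group carrying a single chlorine, or an unsubstituted phenyl group, would compare on this core stays open.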